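Shortening a Sulfonamide Chain in a Series at the Limit

A few compounds are considered here, and "the series" means these few. Any claim that something is new, unique, unknown or untested is made for them only; others in the source may bear on it.

Compound 1 `CCCS(=O)(=O)Nc1cccc2c1CCC2c1ncc[nH]1`: in a functional assay on CHO cells for agonist activity at Alpha-1D adrenergic receptor (Homo sapiens), read by FLIPR and calcium flux (on this read-out lower numbers stand for an effect already at smaller amounts and higher numbers for an effect only at larger amounts of compound), compound 1 gives > 10000 nM, which is a limit of the assay and not a number.
Compound 2 `Cc1c(OCC2=NCCN2)ccc(Cl)c1NS(C)(=O)=O`: compound 2 gives > 10000 nM, also a limit.
Compound 3 `CS(=O)(=O)Nc1c(Cl)ccc2c1CCCC2c1ncc[nH]1`: compound 3 gives > 10000 nM, again a limit.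

All three measured compounds sit at the limit of > 10000 nM in this assay, at which 3 of the 3 values shown sit, so none of them shows an effect within the range of amounts tested. Compound 1 therefore stands at the limit with no number of its own, and its two companions give nothing more precise, so there is no spread of values in which to place it.

Compound 4 `CS(=O)(=O)Nc1cccc2c1CCC2c1ncc[nH]1` keeps the core of compound 1 and differs only at the sulfonamide: hydrogen in place of ethyl on a saturated chain carbon bound to a sulfonyl sulfur. Compound 3 carries the same methanesulfonamido group on a related core and also stops at the limit. Among the compounds with values here, no step between measured compounds is available, so the size of the change from propylsulfonyl to methylsulfonyl cannot be read off here. Given that compound 1 and compound 3 both rest at the limit of > 10000 nM in this assay, at which 3 of the 3 values shown sit, the expected change is a step that the limit leaves unreadable from compound 1 to compound 4, that is, none beyond the usual scatter. Compound 4 is expected to give about 15000 nM, within a range from 5000 nM to 50000 nM, and most likely to be reported again only as a limit.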

Compound 4, half-maximal effective concentration: > 10000 nM
Compound 4: no number, only a limit; the forecaster's own chance of this, stated with the estimate: 80%; the middle value is on the limit's open side.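

Compound 1 and compound 4 both stop at a limit of the assay and not at a number, so no step can be read for the change from propylsulfonyl to methylsulfonyl: the limit of > 10000 nM in this assay, at which 4 of the 4 values shown sit.

The compounds shown leave open whether either sulfonamide chain differs from the other at all, and what structure would give a measurable effect.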